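The compounds below may be only part of what the source reports. "The series", "measured", "known", "first", "only" and "open" are said of these compounds alone.

Within the data shown here, compound 3 `CC(C)N1CCc2nc(C#Cc3cccc(Cl)c3)ccc2C1=O` gives 5.7 nM in a functional assay on HEK293 cells for negative allosteric modulation of metabotropic glutamate receptor 5 (Homo sapiens), read by FLIPR and calcium flux (a lower number here means a stronger inhibitor, a higher number a weaker inhibitor), the lowest of the three numbers known so far. Compound 1 `CN1CCc2nc(C#Cc3cccc(Cl)c3)ccc2C1=O` gives 22 nM, and compound 2 `CC(C)N1CCc2nc(C#Cc3ccccc3)ccc2C1=O` gives 706 nM. Compound 4 `CC(C)N1CCc2nc(C#Cc3cccs3)ccc2C1=O` differs from compound 3 in one place: thiophen-2-yl in place of 3-chlorophenyl on a triple-bonded carbon. The step that bears on this is the one at the same ring, where a chloro in place of hydrogen gave a 120-fold lower number from compound 2 to compound 3 (2.09 log units; beyond the scatter); the change at the amide-type nitrogen, a 3.9-fold lower number from compound 1 to compound 3 (0.59 log units; beyond the scatter), is not touched here. As far as these compounds go, because removing the chloro alone cost a 120-fold lower number from compound 2 to compound 3 (2.09 log units; beyond the scatter), a smaller aromatic ring without it is expected to give a weaker inhibitor, though a five-membered ring is untested and the size of the step is uncertain. The expected change is a 26-fold higher number from compound 3 to compound 4 (1.42 log units; beyond the scatter). Compound 4 is therefore estimated at 150 nM, in a range from 30 nM to 700 nM.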

Compound 4, half-maximal inhibitory concentration: 45 nM
The estimate for compound 4 lay 3.3-fold (0.52 log units) above the measured number; low and high end bracket the measured number.
By their numbers in this assay, from the lowest: compound 3; then compound 1; then compound 4; then compound 2.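

At this triple-bonded carbon, a chloro is not the only route to a much lower number than the unsubstituted phenyl gives. Thiophen-2-yl has no chloro, yet it shows a 16-fold lower number from compound 2 to compound 4 (1.20 log units; beyond the scatter) and still falls short of 3-chlorophenyl, with a 7.9-fold higher number from compound 3 to compound 4 (0.90 log units; beyond the scatter) in place. No measurement shown here explains this difference between the rings. Still open, as far as these compounds go, is whether a chloro on the thiophen-2-yl ring would lower the number further, as it did on phenyl, and how a pyridine ring would compare at this carbon.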